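A few compounds are considered here, and "the series" means these few. Any claim that something is new, unique, unknown or untested is made for them only; others in the source may bear on it.

Measured so far:
- compound 1, `Cc1cccc(NC(=O)CN2CCC(c3ccc(Cl)cc3)CC2)c1` — a functional assay on cells for agonist activity at D(4) dopamine receptor (Homo sapiens), read by TR-FRET and cAMP accumulation, with a stated time of 30 min; a higher number here means that more compound is needed for the effect, a lower number that less compound is needed: "not active" (no number reported)
- compound 2, `O=C(CN1CCN(c2ccccn2)CC1)Nc1cccnc1` — this assay: 1080 nM
- compound 3, `CCc1cccc(NC(=O)CN2CCN(c3ccc(Cl)cn3)CC2)c1` — this assay: "not active" (no number reported)

Compound 1 stands without a number in this assay: it is reported only as inactive, as is compound 3, which has a different core. Compound 2, again on another core, is the only entry with a single value, 1080 nM for compound 2. Going by the values given here, no step between any two measured compounds is available, so nothing can be said of how the change below has behaved elsewhere.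

Compound 4, `Cc1cccc(NC(=O)CN2CCC(c3ccccc3)CC2)c1`, is to be measured in this assay. It differs from compound 1 by hydrogen in place of chloro on an aromatic carbon.

With compound 1 carrying no number, no step size can be anchored. Since compound 1 gives "not active" (no number reported) in this assay, compound 4 is expected to remain at the weak end, with no step beyond the scatter in either direction and a fair chance that again no single number is reported. For compound 4 the estimate in this assay is 10000 nM, within 2000 nM to 50000 nM.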

Compound 4, half-maximal effective concentration: 15.4 nM
For compound 4 the middle estimate is 650-fold (2.81 log units) above the measured one; measured number outside the range, below it.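

No step can be read between compound 1 and compound 4: in this assay compound 1 gives "not active" (no number reported), while compound 4 gives 15.4 nM. The compounds shown leave open how large the change from 4-chlorophenyl to phenyl is, and whether it holds on other cores. No evidence bears on this result.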